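Trading 3-methoxyphenyl for 3,4-dichlorophenyl on the shared core

This account rests on a few compounds, and the source may have more. Where it says the series, first, only, none or still open, it means among the compounds named here.

Compound 1 `CCOC(=O)c1c(-c2ccccc2)[nH]c2cc(OC)ccc2c1=O`, compound 2 `CCOC(=O)c1c(-c2ccccc2Cl)[nH]c2cc(OC)ccc2c1=O` and compound 3 `CCOC(=O)c1c(-c2cccc(OC)c2)[nH]c2cc(OC)ccc2c1=O` share one core and differ only in one aromatic group. In a physicochemical assay for solubility, in phosphate buffer, at pH 7.4 (a higher number here means a more soluble compound, a lower number a less soluble compound), compound 1 gives > 100000 nM, which is a limit of the assay and not a number. Compound 3 gives > 100000 nM, also a limit. Compound 3 therefore stands at the limit of > 100000 nM in this assay, at which 2 of the 3 values shown sit. Compound 2 gives a true number, 28000 nM.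

Compound 4 `CCOC(=O)c1c(-c2ccc(Cl)c(Cl)c2)[nH]c2cc(OC)ccc2c1=O` carries 3,4-dichlorophenyl in place of 3-methoxyphenyl on an aromatic carbon. Among the measured compounds shown here, no measured step makes this exact swap, so the nearest ones must serve. Adding chloro gave an at least 3.5-fold lower number from compound 1 to compound 2 (0.55 log units; beyond the scatter), and going from 2-chlorophenyl to 3-methoxyphenyl gave an at least 3.5-fold higher number from compound 2 to compound 3 (0.55 log units; beyond the scatter). Adding methoxy gave a step that the two limits leave unreadable from compound 1 to compound 3, which says little. Compound 4 has two chloro groups and no methoxy, so a clear drop is expected, at least as large as those readable steps. The expected change is an at least 8.3-fold lower number from compound 3 to compound 4 (0.92 log units; beyond the scatter). Compound 4 is estimated at 12000 nM, with an expected range from 3000 nM to 40000 nM.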

Compound 4, solubility: 17000 nM
Estimate against measurement, compound 4: 1.4-fold (0.15 log units) below, within the range that was stated.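

In this assay, 3,4-dichlorophenyl in place of 3-methoxyphenyl gives an at least 5.8-fold lower number from compound 3 to compound 4 (0.76 log units; beyond the scatter), and in place of plain phenyl it gives an at least 5.8-fold lower number from compound 1 to compound 4 (0.76 log units; beyond the scatter). Both steps start from a value that is a limit and not a number, in compound 1 and in compound 3: the limit of > 100000 nM in this assay, at which 2 of the 4 values shown sit. Against 2-chlorophenyl the change gives a 1.6-fold lower number from compound 2 to compound 4 (0.22 log units; within the scatter), so the two chlorine-bearing compounds cannot be told apart here, and among these four compounds only those with chloro on this aromatic group give true numbers, with one chloro or with two.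

Which of the two chloro groups of 3,4-dichlorophenyl goes with the drop stays open. So does the reading at this position for a phenyl ring that carries an amine or a carboxylic acid.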